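From Chloro to 4-Methylpiperazin-1-yl on Compound 3

The source may report more compounds than this note shows. Statements on the series, on what has been measured and on what is new or still open speak of the compounds shown alone.

Three related compounds have so far been tested in a functional assay on A549 cells (Homo sapiens) for antiproliferative activity, read by MTT assay, with a stated time of 48 h (on this read-out higher numbers stand for weaker inhibition and lower numbers for stronger inhibition), with numeric results. Compound 1 `CO[C@]1(C)/C=C/C(=O)/C(CO)=C\C[C@](C)(CCC=C(C)C)/C=C/[C@H]1OC(=O)C=C(C)C` gives 14400 nM there, compound 2 `C=C1/C=C/C(=O)/C(CO)=C\C[C@](C)(CCC=C(C)C)/C=C/[C@H]1OC(=O)C=C(C)C` gives 3090 nM there, and compound 3 `CC(C)=CCC[C@]1(C)/C=C/[C@@H](OC(=O)C=C(C)C)[C@](C)(O)/C=C/C(=O)/C(CCl)=C\C1` gives 150 nM there. Compound 3 therefore holds the lowest number of the three, and its gaps to both of the others lie beyond the usual scatter of repeat measurements.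

Compound 4 `CC(C)=CCC[C@]1(C)/C=C/[C@@H](OC(=O)C=C(C)C)[C@](C)(O)/C=C/C(=O)/C(CN2CCN(C)CC2)=C\C1` differs from compound 3 in a single place, with 4-methylpiperazin-1-yl in place of chloro on a saturated chain carbon bound to a double-bonded ring carbon. Within the data shown here, no two measured compounds differ in only one place, so nothing measured yet shows what a single change does here, and any expectation must stay loose. A rise seems more likely than a further drop, since compound 3 at 150 nM already sits far under compound 2 at 3090 nM in these data. The estimated step is a 10-fold higher number from compound 3 to compound 4 (1.00 log units; beyond the scatter) in this assay towards weaker inhibition, which would lie beyond the scatter. For compound 4 the expected value is 1500 nM with an estimated range from 300 nM to 8000 nM in this assay.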

Compound 4, half-maximal inhibitory concentration: 940 nM
The estimate for compound 4 lay 1.6-fold (0.20 log units) above the measured number, within the range that was stated.
By their numbers in this assay, from the lowest: compound 3; then compound 4; then compound 2; then compound 1.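

In this assay, among these compounds, replacing chloro with 4-methylpiperazin-1-yl on a saturated chain carbon bound to a double-bonded ring carbon gives the first direct reading of what a single change does: a 6.3-fold higher number from compound 3 to compound 4 (0.80 log units; beyond the scatter), a move towards weaker inhibition. This position is therefore sensitive to the group it carries, yet it tolerates a six-membered non-aromatic ring in place of a lone chlorine without losing all activity, as compound 4 still gives 940 nM in this assay. Nothing measured here explains the rise, so the step remains an observation without a known cause.

One pair cannot separate the effect of losing chloro from the effect of gaining the 4-methylpiperazin-1-yl group, and it cannot show whether the step reflects the whole ring or only part of it. The compounds shown leave open how a smaller amine such as dimethylamino, a morpholin-4-yl ring or another halogen such as bromo would compare with chloro on this same carbon of the shared core.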